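The source may report more compounds than this note shows. Statements on the series, on what has been measured and on what is new or still open speak of the compounds shown alone.

Series notes. In a functional assay on HeLa cells (Homo sapiens) for inhibition, read by MTT assay, with a stated time of 72 h (on this read-out higher numbers stand for weaker inhibition and lower numbers for stronger inhibition), compound 2 `Nc1ncnc2c1c(-c1cnc3[nH]ccc3c1)nn2CCCCCCCCCC(=O)NO` gives 7560 nM. Compound 1 `Nc1ncnc2c1c(-c1cnc3[nH]ccc3c1)nn2CCCCCC(=O)NO` carries the change (hydroxycarbamoyl in place of 4-(hydroxycarbamoyl)butyl on a saturated chain carbon, five bonds along the chain from an aromatic nitrogen). In this assay compound 1 reaches only > 150000 nM, which is a limit of the assay and not a number. The step of an at least 19-fold higher number from compound 2 to compound 1 (1.29 log units; beyond the scatter) is accordingly bounded by the limit of > 150000 nM in this assay, at which 1 of the 3 values shown sits, rather than fixed.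

Compound 3 `Nc1nc2cc(-c3nn(CCCCCC(=O)NO)c4ncnc(N)c34)ccc2o1` has a different core; the difference between the two cores is not broken down here. In this assay compound 3 gives 15400 nM, a higher number than compound 2.

Compound 4 `Nc1nc2cc(-c3nn(CC(=O)NO)c4ncnc(N)c34)ccc2o1` is not yet measured. From compound 3 to compound 4 the change is hydroxycarbamoyl in place of 4-(hydroxycarbamoyl)butyl on a saturated chain carbon bound to an aromatic nitrogen. The place here is on a saturated chain carbon bound to an aromatic nitrogen, whereas in compound 1 it is on a saturated chain carbon five bonds along the chain from an aromatic nitrogen, so this is the same kind of change, not the same change. The step is expected to be a 13-fold higher number from compound 3 to compound 4 (1.11 log units; beyond the scatter), resting on compound 1 having reached the limit of > 150000 nM in this assay, at which 1 of the 3 values shown sits, after the same kind of shortening. Compound 4 is expected to give 200000 nM, between 60000 nM and 600000 nM, and a limit rather than a number is considered likely.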

Compound 4, half-maximal inhibitory concentration: > 150000 nM
Compound 4 ended at the assay's limit (the forecaster's own chance of this, stated with the estimate: 70%); the middle value is on the limit's open side.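

In this assay compound 4 gives > 150000 nM, which is a limit of the assay and not a number. Hydroxycarbamoyl in place of 4-(hydroxycarbamoyl)butyl gives an at least 9.7-fold higher number from compound 3 to compound 4 (0.98 log units; beyond the scatter), so the number rises beyond the scatter on the core of compound 3 as it does on the core of compound 1: the same change on two cores in this assay, an at least 19-fold higher number (1.29 log units; beyond the scatter) from compound 2 to compound 1 and an at least 9.7-fold higher number (0.98 log units; beyond the scatter) from compound 3 to compound 4; the limit leaves it open whether they differ. This shows that the direction of the change carries over between these two cores, but not its size, and the place also differs, being on a saturated chain carbon bound to an aromatic nitrogen in compound 4 and five bonds along the chain from an aromatic nitrogen in compound 1; how far either step really reaches stays unfixed: the limit of > 150000 nM in this assay, at which 2 of the 4 values shown sit.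

The compounds shown leave open how a longer chain, such as the one in compound 2, would read on the core of compound 3. Also open, from the compounds shown here alone, is how a carboxylic acid in place of the hydroxycarbamoyl end would read on either core.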